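The source may report more compounds than this note shows. Statements on the series, on what has been measured and on what is new or still open speak of the compounds shown alone.

Measured compounds:
compound 1, `Cn1nnnc1SCC(=O)N/N=c1/scc(-c2ccc([N+](=O)[O-])cc2)n1-c1ccccc1`, 69.3%;
compound 2, `Cn1cnnc1SCC(=O)N/N=c1/scc(-c2ccccc2)n1-c1ccccc1`, 77.3%.

The account concerns two measured compounds and one that is not yet measured. In a functional assay on C6 cells (Rattus norvegicus) for cytotoxicity, read by MTT assay, with a stated time of 24 h, tested at 25 ug/mL (a lower number here means a stronger effect, a higher number a weaker effect of the compound at the concentration tested), compound 1 gives 69.3%, and in this assay compound 2 gives 77.3%. Compound 2 has the higher of the two numbers, but compound 1 lies within the scatter of it, so the two values show no real difference between them. Among the compounds with values here, compound 1 and compound 2 differ in two places at once, so no single step between them can be read off.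

Compound 3, `Cn1nnnc1SCC(=O)N/N=c1/scc(-c2ccccc2)n1-c1ccccc1`, is the next compound. Compared with compound 2 it carries 1-methyl-1H-tetrazol-5-yl in place of 4-methyl-4H-1,2,4-triazol-3-yl on a sulfur. Compound 1 already contains the 1-methyl-1H-tetrazol-5-yl group and gives a value close to that of compound 2, so the change from compound 2 to compound 3 is expected to move this assay little, in no firm direction, and not beyond the scatter. The expected step is a number 4.3 percentage points lower from compound 2 to compound 3 (within the scatter). For compound 3 the estimate in this assay is 73%, with a range from 60% to 86%.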

Compound 3, a percentage reported as activity, at one concentration (the size of the read-out at that concentration, not a potency): 64.2%
Beside the measured number, compound 3's estimate is 8.8 percentage points above it; low and high end bracket the measured number.
By their numbers in this assay, from the lowest: compounds 3, 1 and 2 (each within the scatter of the next, the first and the last beyond it).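

In this assay, within the data shown here, 1-methyl-1H-tetrazol-5-yl in place of 4-methyl-4H-1,2,4-triazol-3-yl on a sulfur gives a number 13.1 percentage points lower from compound 2 to compound 3 (beyond the scatter), the first single change that can be read on its own, and it shows that this exchange on a sulfur can carry a step that stands clear of the usual scatter. With 1-methyl-1H-tetrazol-5-yl held in place, hydrogen in place of nitro on an aromatic carbon gives a number 5.1 percentage points lower from compound 1 to compound 3 (within the scatter), so at this read-out that second change cannot be told apart from no change at all. Nothing measured here bears on what lies behind either step.

The compounds shown leave open whether the exchange on a sulfur gives a step of similar size when nitro stands on the aromatic carbon, as only one of the two partners for that comparison is present. They also leave open how an amine or a carboxylic acid in place of nitro, or an ethyl group in place of the methyl on the sulfur-bound ring, would read at this single concentration.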